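Compound 1 to compound 4: exchanging one ring group

A few compounds are considered here, and "the series" means these few. Any claim that something is new, unique, unknown or untested is made for them only; others in the source may bear on it.

Measured in a functional assay on SH-SY5Y cells (Homo sapiens) for cytotoxicity, read by MTT assay, with a stated time of 72 h; a lower number here means a stronger inhibitor, a higher number a weaker inhibitor:
- Compound 1 `O=C1c2c[n+]([O-])c3ccccc3c2C(=O)c2c1c1ccccc1n2Cc1cn([C@@H]2C[C@H](O)[C@@H](CO)O2)nn1`: 150 nM
- Compound 2 `CN1CCN(CCCCn2c3c(c4ccccc42)C(=O)c2c[n+]([O-])c4ccccc4c2C3=O)CC1`: 100 nM
- Compound 3 `O=C1c2c[n+]([O-])c3ccccc3c2C(=O)c2c1c1ccccc1n2CCN1CCCC1`: 520 nM

In this assay, compound 1 at 150 nM lies within the scatter of compound 2 at 100 nM. Compound 3 at 520 nM has a higher number than either, beyond the scatter. Compound 4 `CC1(C)O[C@@H](CO)[C@H](Cn2cc(Cn3c4c(c5ccccc53)C(=O)c3c[n+]([O-])c5ccccc5c3C4=O)nn2)O1` keeps the core of compound 1 and changes the group on an aromatic nitrogen of the five-membered aromatic ring with 3 nitrogen: (5-(hydroxymethyl)-2,2-dimethyl-1,3-dioxolan-4-yl)methyl in place of 4-hydroxy-5-(hydroxymethyl)oxolan-2-yl on an aromatic nitrogen. Within the data shown here, no measured step covers this exchange. The only one available, a 5.2-fold higher number from compound 2 to compound 3 (0.72 log units; beyond the scatter), is modest and involves a different group, so it bears on the change only loosely. It suggests that an exchange of this kind could move the number modestly, but it gives no firm direction. The step expected is a 1.3-fold higher number from compound 1 to compound 4 (0.12 log units; within the scatter), not beyond the scatter. Compound 4 is therefore estimated at 200 nM, with an expected range of 70 nM to 550 nM.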

Compound 4, half-maximal inhibitory concentration: > 1000 nM
Compound 4: a limit, no number; the forecaster's own chance of this, stated with the estimate: 3%; at least 5.0-fold (0.69 log units) between middle value and limit.
By their numbers in this assay, from the lowest: compounds 2 and 1 (each within the scatter of the next); then compound 3. At a limit, above all of these: compound 4.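

In this assay compound 4 gives > 1000 nM, which is a limit of the assay and not a number: the limit of > 1000 nM in this assay, at which 1 of the 4 values shown sits. The group on the aromatic nitrogen of the five-membered aromatic ring with 3 nitrogen is therefore not a free place to change, as shown by an at least 6.6-fold higher number from compound 1 to compound 4 (0.82 log units; beyond the scatter). The earlier step between compounds 2 and 3 concerned a different group and could not show this. From the compounds shown here alone, the new step rests on a limit, and its true size remains unknown.

The pair does not separate the ring exchange from the loss of one hydrogen-bond donor or the gain in heavy atoms, since all of these change together. It also leaves open how a carboxylic acid or an amine at this same place would read in this assay.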